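Working notes: from compound 2 to compound 3

This account rests on a few compounds, and the source may have more. Where it says the series, first, only, none or still open, it means among the compounds named here.

- compound 1 `CCN(Cc1cc(N2CCN(C)CC2)nc(C)n1)C1CCCc2cccnc21` - 0.0325 h
- compound 2 `CCN1CCN(c2cc(CN(C)[C@H]3CCCc4cccnc43)nc(C)n2)CC1` - 0.019 h

Both compounds were read in an ADME assay on microsomes from liver (Rattus norvegicus) for metabolic stability, read by LC-MS, using NADPH, with stated times of 10 min and 60 min (on this read-out higher numbers stand for a longer-lived compound and lower numbers for a shorter-lived compound), and compound 2 (0.019 h) lies within the scatter of compound 1. Compound 3 `Cc1nc(CN(C)[C@H]2CCCc3cccnc32)cc(N2CCN(C)[C@H](C)C2)n1` departs from compound 2 by 3,4-dimethylpiperazin-1-yl in place of 4-ethylpiperazin-1-yl on an aromatic carbon on an aromatic carbon, with the same atoms joined differently. Among the compounds with values here, no measured pair shows this change, so with compound 2 at 0.019 h as the reference, no step beyond the scatter is expected in this assay in either direction. The estimate means a 1.1-fold higher number from compound 2 to compound 3 (0.02 log units; within the scatter) as an expected step. Compound 3 is estimated at 0.02 h with 0.01 h to 0.04 h as the expected range.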

Compound 3, half-life: < 0.0167 h
Compound 3: a limit, no number (the forecaster's own chance of this, stated with the estimate: 3%); at least 1.1-fold (0.07 log units) between middle value and limit.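

In this assay, 3,4-dimethylpiperazin-1-yl in place of 4-ethylpiperazin-1-yl gives the first step read at this position: an at least 1.1-fold lower number from compound 2 to compound 3 (0.05 log units; that floor lies within the scatter). With the same atoms joined differently, this change brings no longer half-life at this aromatic carbon. The value of compound 3 is a limit, not a number, so the step has only a floor: the limit of < 0.0167 h in this assay, at which 1 of the 3 values shown sits.

Still open, going by these compounds, is how a morpholine, or a piperazine carrying a hydroxyethyl chain, would read at this position in this assay. How far compound 3 truly lies from compound 2 also remains unresolved.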